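The source may report more compounds than this note shows. Statements on the series, on what has been measured and on what is new or still open speak of the compounds shown alone.

Of the compounds shown here, three built on one shared core have been measured in an ADME assay on the whole organism (Mus musculus, strain BALB/C) for pharmacokinetics, read by LC-MS, with a stated time of 24 h, at a dose of 1 mg/kg by the intravenous route; on this read-out lower numbers stand for narrower distribution and higher numbers for wider distribution into tissues. Compound 1 `C[C@H](Nc1nc(N)nc(N)c1C#N)c1cc2ccc(F)cn2c(=O)c1-c1ccccc1` gives 1.3 L/kg. Compound 2 `Cc1c([C@H](C)Nc2nc(N)nc(N)c2C#N)c(-c2ccccc2)c(=O)n2cc(F)ccc12` gives 1.7 L/kg, and compound 3 `C[C@H](Nc1nc(N)nc(N)c1C#N)c1c(-c2ccccc2)c(=O)n2cc(F)ccc2c1C1CC1` gives 1.8 L/kg. Compound 3 holds the highest of the three numbers, but only by margins the assay cannot resolve: a 1.4-fold higher number from compound 1 to compound 3 (0.14 log units; within the scatter) and a 1.1-fold higher number from compound 2 to compound 3 (0.02 log units; within the scatter), both within the scatter, as is a 1.3-fold higher number from compound 1 to compound 2 (0.12 log units; within the scatter). Compound 4 `C[C@H](Nc1nc(N)nc(N)c1C#N)c1c(-c2ccccc2)c(=O)n2cc(F)ccc2c1-c1ccc(F)cc1` has not yet been measured. It differs from compound 3 at a single place: 4-fluorophenyl in place of cyclopropyl on an aromatic carbon. All three measured steps swap groups at this very aromatic carbon, and none of them shifted the number beyond the scatter, although the group entering here is larger than any of those already tried. The step of a 1.1-fold higher number from compound 3 to compound 4 (0.05 log units; within the scatter) is therefore expected to be small, at most a slight rise that stays inside the usual scatter. Compound 4 is estimated to give 2 L/kg, within a range from 1.2 L/kg to 3.5 L/kg.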

Compound 4, volume of distribution at steady state: 0.7 L/kg
The estimate for compound 4 lay 2.9-fold (0.46 log units) above the measured number; measured number below the stated range.
By their numbers in this assay, from the lowest: compounds 4, 1, 2 and 3 (each within the scatter of the next, the first and the last beyond it).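

In this assay, within the data shown here, this aromatic carbon proves less indifferent than the earlier compounds suggested: hydrogen, methyl and cyclopropyl stay within the scatter of one another, whereas 4-fluorophenyl brings a 2.6-fold lower number from compound 3 to compound 4 (0.41 log units; beyond the scatter) and a 2.4-fold lower number from compound 2 to compound 4 (0.39 log units; beyond the scatter), both modest but beyond the scatter. Against hydrogen the same group gives a 1.9-fold lower number from compound 1 to compound 4 (0.27 log units; within the scatter), so the drop is clear against methyl and cyclopropyl but not against hydrogen, and a larger group here does not simply carry the number upward. Nothing shown here accounts for this drop.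

The compounds shown leave open whether the change comes from the aromatic ring or from its fluorine, which a plain phenyl at this carbon would help separate. They also leave open how an amine or a carboxylic acid here would behave.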